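Replacing fluoro with hydrogen in compound 1

A few compounds are considered here, and "the series" means these few. Any claim that something is new, unique, unknown or untested is made for them only; others in the source may bear on it.

Measured in an ADME assay on HUVEC cells (Homo sapiens) for cytotoxicity, read by MTT assay, with a stated time of 48 h (a lower number here means a stronger inhibitor, a higher number a weaker inhibitor), so far
- compound 1 `CC(C)(Oc1ccc(Cl)cc1)C(=O)NCCOC(=S)Nc1ccc(F)cc1` gives 773000 nM
- compound 2 `Cc1ccc(NC(=S)OCCNC(=O)c2cccnc2)cc1` gives 567000 nM
- compound 3 `Cc1cnc(C(=O)OCCCOC(=O)CCCCC2CCSS2)c[n+]1[O-]` gives > 800000 nM as a limit and not a number

Compound 1 stands within the usual scatter of compound 2, so the two cannot be told apart. Compound 3 offers no number to compare. Compound 4 `CC(C)(Oc1ccc(Cl)cc1)C(=O)NCCOC(=S)Nc1ccccc1` has not yet been measured. It differs from compound 1 by hydrogen in place of fluoro on an aromatic carbon para to a large group. Within the data shown here, no measured pair shows this change, so no step beyond the scatter is expected in this assay and no direction is predicted. The estimated change reads a 1.1-fold lower number from compound 1 to compound 4 (0.04 log units; within the scatter) here. Compound 4 is estimated at 700000 nM with an expected range of 400000 nM to 1000000 nM around that figure.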

Compound 4, half-maximal inhibitory concentration: 791000 nM
For compound 4 the middle estimate is 1.1-fold (0.05 log units) below the measured one, and the stated range covers the measured number.
By their numbers in this assay, from the lowest: compounds 2, 1 and 4 (each within the scatter of the next). At a limit, above all of these: compound 3.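

In this assay, this first measured pair differing at this position reads a 1.0-fold higher number from compound 1 to compound 4 (0.01 log units; within the scatter). Fluoro and hydrogen on this aromatic carbon therefore cannot be told apart in cytotoxicity on these cells. The pair also stands close to the top of what the assay reports, which leaves little room to see any change here: the limit of > 800000 nM in this assay, at which 1 of the 4 values shown sits.

Still open, going by these compounds, is whether a different group at this position, such as an amine, a carboxylic acid or a methoxy group, would give a number clear of the scatter. Whether the same swap reads alike on a different core is open too.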